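The source may hold more compounds than are shown below. What is called first, only, known or untested is meant among the compounds shown, and "the series" means these compounds.

Measured so far in an assay on isolated protein for inhibition of histamine H2 receptor (Cavia porcellus); on this read-out lower numbers stand for tighter binding and higher numbers for weaker binding:
compound 1 `COc1ccc(NC(=O)NCCCOc2cccc(CN3CCCCC3)c2)c(OC)c1`: 2240 nM
compound 2 `Cc1ccc(NC(=O)NCCCOc2cccc(CN3CCCCC3)c2)cc1`: 631 nM
compound 3 `CCCCNC(=O)NCCCOc1cccc(CN2CCCCC2)c1`: 81.3 nM

Compound 3 stands lowest of the three: a 7.8-fold lower number from compound 2 to compound 3 (0.89 log units; beyond the scatter) and a 28-fold lower number from compound 1 to compound 3 (1.44 log units; beyond the scatter), both beyond the scatter, while a 3.5-fold lower number from compound 1 to compound 2 (0.55 log units; beyond the scatter) is the smaller of the steps. Compound 4 `CCCNC(=O)NCCCOc1cccc(CN2CCCCC2)c1` differs from compound 3 by hydrogen in place of methyl on a saturated chain carbon, three bonds along the chain from an amide-type nitrogen. Among the measured compounds shown here, none of the measured steps shortens a chain. Each of them exchanges the whole group on that nitrogen, so they bear on this change only loosely. The steps toward butyl gave lower numbers, but trimming one carbon from the butyl is a far smaller change. No step beyond the scatter is expected in this assay. For compound 4 the expected step is a 1.2-fold higher number from compound 3 to compound 4 (0.09 log units; within the scatter), giving an estimate of 100 nM (range 40 nM to 250 nM).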

Compound 4, dissociation constant: 97.7 nM
Estimate against measurement, compound 4: 1.0-fold (0.01 log units) above; the range from low to high includes it.
By their numbers in this assay, from the lowest: compounds 3 and 4 (each within the scatter of the next); then compound 2; then compound 1.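

In this assay, among the compounds shown here, trimming butyl to propyl on the amide-type nitrogen gives a 1.2-fold higher number from compound 3 to compound 4 (0.08 log units; within the scatter), which reads chain length at this position directly, where the earlier steps exchanged the whole group. Propyl keeps the advantage over both aryl groups, with a 6.5-fold lower number from compound 2 to compound 4 (0.81 log units; beyond the scatter) and a 23-fold lower number from compound 1 to compound 4 (1.36 log units; beyond the scatter), so the terminal methyl of the butyl is not needed for that advantage in these compounds. No independent data on why these numbers fall as they do accompany this result. Still open, on these data alone, is whether ethyl, methyl, a longer chain such as pentyl, or a terminal amine would stay at this level.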